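From (cyclopropylsulfonyl)amino to methyl(methylsulfonyl)amino on the shared core

The source may report more compounds than this note shows. Statements on the series, on what has been measured and on what is new or still open speak of the compounds shown alone.

Two compounds have numbers in an assay on isolated protein for binding affinity to Alpha-1A adrenergic receptor (Rattus norvegicus), read by radioligand binding; a lower number here means a stronger inhibitor, a higher number a weaker inhibitor. Compound 1 `O=S(=O)(Nc1cccc2c1CCCC2c1c[nH]cn1)C1CC1` gives 537 nM, the higher of the two. Among the compounds with values here, compound 2 `CCS(=O)(=O)Nc1cccc(Cc2c[nH]cn2)c1C`, built on a different frame, gives 129 nM, a lower number that lies beyond the scatter; no single-point step joins the pair, so the two values show only that compound 2 is the stronger binder of the two. Compound 3 `CN(c1cccc2c1CCCC2c1c[nH]cn1)S(C)(=O)=O` has not yet been measured. It differs from compound 1 in one place: methyl(methylsulfonyl)amino in place of (cyclopropylsulfonyl)amino on an aromatic carbon. The leaving group carries one hydrogen-bond donor, the entering group carries none, and the entering group has one heavy atom fewer. Within the data shown here, no measured pair in this set tests such a swap, so the expectation rests on the structural change alone and on where compound 1 already stands. For compound 3 a weakening step a 2.2-fold higher number from compound 1 to compound 3 (0.35 log units; beyond the scatter) is expected, somewhat beyond the usual scatter, given that compound 1 itself gives 537 nM at the weak end of the known numbers. The estimate for compound 3 in this assay is 1200 nM, with a range from 300 nM to 5000 nM.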

Compound 3, inhibition constant: 204 nM
Compound 3: the middle estimate sits 5.9-fold (0.77 log units) above what was measured, and the stated range ends above it.
By their numbers in this assay, from the lowest: compounds 2 and 3 (each within the scatter of the next); then compound 1.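

Within the data shown here, on the aromatic carbon of the shared core, methyl(methylsulfonyl)amino in place of (cyclopropylsulfonyl)amino gives a 2.6-fold lower number from compound 1 to compound 3 (0.42 log units; beyond the scatter) in this assay, the first single-point step in this set. Binding at this position therefore does not depend on the hydrogen-bond donor of the leaving group or on its three-membered ring, since a group with neither gives the lower number. The step changes several things at once, with the hydrogen on nitrogen replaced by methyl and the cyclopropyl on sulfur replaced by methyl, and nothing on hand gives a reason for the shift.

Going by these compounds, what stays open is which of these two edits carries the change: (methylsulfonyl)amino, with the hydrogen kept on nitrogen, and methyl(cyclopropylsulfonyl)amino would each separate one edit from the other on the shared core. Also open, on these data alone, is whether the sulfonyl itself matters at this position, which an acetylamino group or a plain dimethylamino group on the same aromatic carbon would test, as would a longer chain such as ethyl on the nitrogen for the size of group tolerated there.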